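Working notes: 3-methoxyphenyl to 2-methoxyphenyl

This account rests on a few compounds, and the source may have more. Where it says the series, first, only, none or still open, it means among the compounds named here.

In a functional assay on L1210 cells (Mus musculus) for antiproliferative activity, read by MTT assay, with a stated time of 72 h (on this read-out lower numbers stand for stronger inhibition and higher numbers for weaker inhibition), compound 1 (`COc1cc(C2=NN(C(C)=O)C(c3cccc([N+](=O)[O-])c3)O2)cc(OC)c1OC`) gives 39000 nM. In the same assay, compound 2 (`COc1cccc(C2OC(c3cc(OC)c(OC)c(OC)c3)=NN2C(C)=O)c1`) gives 45000 nM. These two values lie within the scatter of each other, so compound 2 stands level with compound 1 and neither can be ranked.

Compound 3 (`COc1ccccc1C1OC(c2cc(OC)c(OC)c(OC)c2)=NN1C(C)=O`) keeps the core of compound 2 and carries 2-methoxyphenyl in place of 3-methoxyphenyl on a saturated ring carbon.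

Among the compounds with values here, only one measured step bears on this change, and it bears indirectly: a 1.2-fold higher number from compound 1 to compound 2 (0.06 log units; within the scatter). Within the data shown here, that step exchanges nitro for methoxy on an aromatic carbon, whereas the new change relocates the methoxy group, and no measured pair tests such an isomer directly. On this thin evidence, no step beyond the scatter is expected in this assay, and neither direction is favoured. The estimate for compound 3 is 42000 nM, with an expected range of 16000 nM to 100000 nM. This estimate means an expected 1.1-fold lower number from compound 2 to compound 3 (0.03 log units; within the scatter).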

Compound 3, half-maximal inhibitory concentration: 48000 nM
For compound 3 the middle estimate is 1.1-fold (0.06 log units) below the measured one, within the range that was stated.
By their numbers in this assay, from the lowest: compounds 1, 2 and 3 (each within the scatter of the next).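

In this assay, the direct test of where the methoxy sits on the aryl group at this saturated ring carbon gives a 1.1-fold higher number from compound 2 to compound 3 (0.03 log units; within the scatter), so 2-methoxyphenyl and 3-methoxyphenyl stand level here and cannot be ranked. The comparison with the nitro compound reads the same way, with a 1.2-fold higher number from compound 1 to compound 3 (0.09 log units; within the scatter), so 2-methoxyphenyl and 3-nitrophenyl cannot be ranked either. Compounds 1, 2 and 3 therefore form one level group, and neither the two methoxy placements nor the exchange of 3-nitrophenyl for 2-methoxyphenyl separates them at this carbon.

The compounds shown leave open whether any group on this aryl ring can shift the number beyond the scatter, for instance an amine, a carboxylic acid or a longer alkoxy chain in place of the methoxy, and whether exchanging the acetyl group of the shared core for a longer acyl chain would do so in this assay. Nothing available here accounts for the level standing of the three compounds.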